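The source may hold more compounds than are shown below. What is called first, only, known or untested is meant among the compounds shown, and "the series" means these compounds.

Compound 1 `CC(C)Cn1c(=O)n(C)c(=O)c2[nH]c(=O)c(Cc3cccc4ccccc34)nc21`: > 10000 nM
Compound 2 `CC(C)Cn1c(=O)n(C)c(=O)c2nc(C(=O)NCCCO)c(Cc3cccc4ccccc34)nc21`: > 10000 nM

Both entries come from a functional assay on Raji cells (Homo sapiens) for inhibition, read by MTT assay, with a stated time of 96 h; a higher number here means that more compound is needed for the effect, a lower number that less compound is needed. Compound 1 gives > 10000 nM, which is a limit of the assay and not a number. Compound 2 gives > 10000 nM, which is likewise only a limit. Compound 2 therefore has no exact value and sits at the limit of > 10000 nM in this assay, at which 2 of the 2 values shown sit.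

Compound 3 `CC(C)Cn1c(=O)n(C)c(=O)c2nc(/C=C\CCCO)c(Cc3cccc4ccccc34)nc21` is reached from compound 2 by one change on an aromatic carbon, ortho to a (naphthalen-1-yl)methyl group: 5-hydroxypent-1-en-1-yl in place of (3-hydroxypropyl)carbamoyl. The counted difference is 5-hydroxypent-1-en-1-yl in place of (3-hydroxypropyl)carbamoyl on an aromatic carbon.

Going by the values given here, no two measured compounds differ in just one place, so no earlier step shows how large this one might be. Among the compounds with values here, the only starting point is compound 2, with its limit of > 10000 nM, and this points in neither direction. The expected change is therefore no more than the usual scatter, in no particular direction: a number no higher from compound 2 to compound 3 (the limit leaves the size open). this assay may well return only a limit again. For compound 3 the estimated value is 10000 nM, with an expected range from 3000 nM to 30000 nM.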

Compound 3, half-maximal effective concentration: 70 nM
Estimate against measurement, compound 3: 140-fold (2.15 log units) above; measured number below the stated range.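

In this assay, replacing (3-hydroxypropyl)carbamoyl with 5-hydroxypent-1-en-1-yl gives an at least 140-fold lower number from compound 2 to compound 3 (2.15 log units; beyond the scatter), the first measurable number among the compounds shown. This aromatic carbon, ortho to a (naphthalen-1-yl)methyl group, is therefore a place where a single change can move the result well beyond the usual scatter, something the earlier limits could not reveal. The printed step is only a minimum because the starting point is a limit and not a number: the limit of > 10000 nM in this assay, at which 2 of the 3 values shown sit.

The change replaces a group with 7 heavy atoms, 2 hydrogen-bond donors and 2 hydrogen-bond acceptors by one with 6 heavy atoms, 1 donor and 1 acceptor, and it also alters the chain itself, so the compounds shown cannot tell which part of the swap matters. As far as these compounds go, it remains open whether the double bond or the hydroxyl of the new chain is needed, and how a saturated pentyl chain, a longer chain, or a chain ending in an amine or a carboxylic acid would fare at this position.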